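A few compounds are considered here, and "the series" means these few. Any claim that something is new, unique, unknown or untested is made for them only; others in the source may bear on it.

Measured in a functional assay on MCF7 cells (Homo sapiens) for cytotoxicity; on this read-out lower numbers stand for stronger inhibition and higher numbers for weaker inhibition:
- compound 1 `Cc1cc(-c2nc3cccc(O)c3s2)ccc1N`: 90800 nM
- compound 2 `Cc1cc(-c2nc3c(O)cccc3s2)ccc1N`: > 100000 nM (a limit of the assay)

Compound 2 gives > 100000 nM, which is a limit and not a number. It sits at the limit of > 100000 nM in this assay, at which 1 of the 2 values shown sits.

Compound 3 `Cc1cc(-c2nc3ccccc3s2)ccc1N` differs from compound 2 in one place: hydrogen in place of hydroxy on an aromatic carbon. This puts hydrogen in place of hydroxy on an aromatic carbon. Among the measured compounds shown here, no measured pair shows directly what this change does.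

Both measured compounds carry a hydroxy, and compound 1, at 90800 nM, is also weak in this assay. For the measured compounds named here, compound 3 is the only one here without that group, so a large step towards lower numbers, well beyond the usual scatter, is expected, though this is a judgement with wide uncertainty. The expected change is an at least 10000-fold lower number from compound 2 to compound 3 (4.00 log units; beyond the scatter). The estimated value for compound 3 is 10 nM, with an expected range of 0.5 nM to 1000 nM.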

Compound 3, half-maximal inhibitory concentration: < 1 nM
Compound 3 gave a limit, no number; the forecaster's own chance of this, stated with the estimate: 25%; at least 10-fold (1.00 log units) between middle value and limit.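

Both earlier compounds carry a hydroxy, so only now does this assay show how the shared core behaves without that group: hydrogen in place of hydroxy gives an at least 100000-fold lower number from compound 2 to compound 3 (5.00 log units; beyond the scatter), and the same change at the other hydroxy place gives an at least 90000-fold lower number from compound 1 to compound 3 (4.95 log units; beyond the scatter). Compound 3 gives a limit and not a number: the limit of < 1 nM in this assay, at which 1 of the 3 values shown sits. Compound 2 also gives a limit and not a number: the limit of > 100000 nM in this assay, at which 1 of the 3 values shown sits.

Going by these compounds, how strong compound 3 really is, and so the true size of both steps, stays open. On these data alone, it is also open why the hydroxy has so large an effect, and whether a methoxy or a fluorine atom on this aromatic carbon would keep the low number of compound 3 or return to the weak results of compound 1 and compound 2.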